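A few compounds are considered here, and "the series" means these few. Any claim that something is new, unique, unknown or untested is made for them only; others in the source may bear on it.

Compound 1, `CCc1cc(C(C)=O)c(O)cc1OCCCC(C)(C)c1nnn[nH]1`, in an assay on isolated protein for binding affinity to leukotriene B4 receptor 1 (Homo sapiens), tested at 1 uM (on this read-out higher numbers stand for more inhibition at the one concentration tested (going by the name of the read-out) and lower numbers for less inhibition), gives 76%.
Compound 2, `CCc1cc(C(C)=O)c(O)cc1OCCCCCCC(C)(C)c1nnn[nH]1`, gives 67%.

Compound 2 holds the lower of the two numbers, and its gap to compound 1 lies within the scatter, so no order between the two is claimed. Compound 3, `CCc1cc(C(C)=O)c(O)cc1OCCCCCCC(=O)O`, differs from compound 2 by carboxy in place of 1-(1H-tetrazol-5-yl)-1-methylethyl on a saturated chain carbon, six bonds along the chain from an oxygen on an aromatic ring. For the measured compounds named here, no measured pair shows this change, so its size is open; in this assay a modest decrease is expected, possibly no larger than the scatter. Compound 3 is expected to give 55%, within 30% to 78%. The expected step is a number 12 percentage points lower from compound 2 to compound 3 (beyond the scatter).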

Compound 3, a percentage reported as inhibition, at one concentration (the size of the read-out at that concentration, not a potency): 38%
The estimate for compound 3 lay 17 percentage points above the measured number; the range from low to high includes it.
By their numbers in this assay, from the lowest: compound 3; then compounds 2 and 1 (each within the scatter of the next).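

Carboxy in place of 1-(1H-tetrazol-5-yl)-1-methylethyl gives a number 29 percentage points lower from compound 2 to compound 3 (beyond the scatter) in this assay and shows that the group at the end of the chain affects this read-out. Read with the chain included, 3-carboxypropyl in place of 1-(1H-tetrazol-5-yl)-1-methylethyl gives a number 38 percentage points lower from compound 1 to compound 3 (beyond the scatter) as the larger step. Nothing available explains either step.

Still open, going by these compounds, is whether the loss follows the carboxy group itself or the absence of the two methyl groups. A 1-carboxy-1-methylethyl end and a plain 1H-tetrazol-5-yl end on the same chain would separate the two.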